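The source may report more compounds than this note shows. Statements on the series, on what has been measured and on what is new or still open speak of the compounds shown alone.

Three measured compounds form the background. Compound 3 `O=C1/C(=C/c2ccc(O)cc2)Cc2ccccc2/C1=C\c1ccc([N+](=O)[O-])cc1` carries a 4-hydroxyphenyl group, and in a functional assay on HL-60 cells (Homo sapiens) for cytotoxicity (on this read-out lower numbers stand for higher toxicity in this test and higher numbers for lower toxicity in this test), compound 3 gives 2500 nM. Compound 1 `COc1cc(/C=C2\Cc3ccccc3/C(=C\c3ccc([N+](=O)[O-])cc3)C2=O)ccc1O` differs from it by methoxy in place of hydrogen on an aromatic carbon; in this assay compound 1 gives 950 nM, a step of a 2.6-fold lower number from compound 3 to compound 1 (0.42 log units; beyond the scatter). Compound 2 `COc1ccc(/C=C2\CCC/C(=C\c3ccc([N+](=O)[O-])cc3)C2=O)cc1OC` has a different core, and the difference between the two cores is not broken down here. In this assay compound 2 gives 4300 nM, a number that lies near that of compound 3 and clearly above that of compound 1.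

Compound 4 `COc1cc(/C=C2\CCC/C(=C\c3ccc([N+](=O)[O-])cc3)C2=O)cc(OC)c1OC` has not been measured. It differs from compound 2 by methoxy in place of hydrogen on an aromatic carbon. Among the compounds with values here, this is the same kind of change as the one between compound 3 and compound 1, not the same change: in compound 4 the entering methoxy sits ortho to a methoxy group and meta to a methoxy group, while in compound 1 it sits ortho to a hydroxy group. Within the data shown here, the only guide is a 2.6-fold lower number from compound 3 to compound 1 (0.42 log units; beyond the scatter). The step expected from compound 2 to compound 4 in this assay is a 1.7-fold lower number from compound 2 to compound 4 (0.24 log units; within the scatter), somewhat smaller than that earlier step given the different surroundings. Compound 4 is therefore estimated at 2500 nM in this assay, with a likely range from 900 nM to 7000 nM.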

Compound 4, half-maximal cytotoxic concentration: 1100 nM
Beside the measured number, compound 4's estimate is 2.3-fold (0.36 log units) above it; the range from low to high includes it.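

In this assay the new step is a 3.9-fold lower number from compound 2 to compound 4 (0.59 log units; beyond the scatter). Set beside the earlier case, the methoxy change carries over from one core to the other with no difference that can be told from scatter: the same change on two cores in this assay, a 2.6-fold lower number (0.42 log units; beyond the scatter) from compound 3 to compound 1 and a 3.9-fold lower number (0.59 log units; beyond the scatter) from compound 2 to compound 4, 1.5-fold (0.17 log units) apart, within the scatter of two such steps. Within the data shown here, this agreement rests on only two pairs, with the entering methoxy in different surroundings in each, so it shows that the change lowers the number on both of these cores by a similar amount, but it does not show that the same would hold on any further core or at another place on the ring, nor does it explain why the number falls.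

On these data alone, the aromatic substituents varied here are only hydroxy and methoxy, so it remains open whether an amine, a carboxylic acid or a longer chain such as butoxy at that place would give a step of similar size. Also open, as far as these compounds go, is how the step would behave if the nitro group on the other aromatic ring were replaced.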